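The source may hold more compounds than are shown below. What is called first, only, known or untested is meant among the compounds shown, and "the series" means these compounds.

Measured in an ADME assay on L1210/0 cells (Mus musculus) for cytotoxicity, with a stated time of 48 h; a higher number here means a weaker inhibitor, a lower number a stronger inhibitor:
- compound 1 `O=c1[nH]c(=O)n([C@H]2C[C@H](O)[C@@H](CO)O2)cc1/C=N/O`: 15500 nM
- compound 2 `C=Cc1cn([C@H]2C[C@H](O)[C@@H](CO)O2)c(=O)[nH]c1=O`: 14200 nM
- compound 3 `O=c1[nH]c(=O)n([C@H]2C[C@H](O)[C@@H](CO)O2)cc1/C=C/Cl`: > 200000 nM

Compound 3 has no number, only a limit: the limit of > 200000 nM in this assay, at which 1 of the 3 values shown sits.

The next change leads to compound 4 `CCCC/C=C\c1cn([C@H]2C[C@H](O)[C@@H](CO)O2)c(=O)[nH]c1=O`, with hex-1-en-1-yl in place of 2-chloroethenyl on an aromatic carbon.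

Among the compounds with values here, three measured steps concern this same position. The step of a 1.1-fold lower number from compound 1 to compound 2 (0.04 log units; within the scatter) is small. The steps of an at least 12-fold higher number from compound 1 to compound 3 (1.11 log units; beyond the scatter) and an at least 14-fold higher number from compound 2 to compound 3 (1.14 log units; beyond the scatter) are both large, so changes at this position can shift this assay substantially. None of the three compounds carries a chain as long as hex-1-en-1-yl, so the direction rests on weak evidence. Compound 3 sits at a limit, which leaves room for a measurable change only towards a lower number. A moderate step in that direction is expected, though compound 4 may also reach the limit.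

The expected step is an at least 2.2-fold lower number from compound 3 to compound 4 (0.34 log units; beyond the scatter).

The estimate for compound 4 is 90000 nM, with an expected range of 25000 nM to 200000 nM.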

Compound 4, half-maximal inhibitory concentration: > 200000 nM
Compound 4: a limit, no number; the forecaster's own chance of this, stated with the estimate: 45%; middle value at least 2.2-fold (0.34 log units) away from the limit.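

In this assay compound 4 gives > 200000 nM, a limit and not a number, so the steps that join two limits cannot be read, and replacing 2-chloroethenyl with hex-1-en-1-yl yields no measurable value: the limit of > 200000 nM in this assay, at which 2 of the 4 values shown sit.

Measured against the two compounds with numbers, the change is large: an at least 14-fold higher number from compound 2 to compound 4 (1.14 log units; beyond the scatter) and an at least 12-fold higher number from compound 1 to compound 4 (1.11 log units; beyond the scatter). At this position, then, a longer carbon chain on the double bond does not keep the values seen with vinyl and with the group of compound 1.

As far as these compounds go, it remains open whether a chain of intermediate length, such as a butenyl group, would give a number between vinyl and the limit. Also open, from the compounds shown here alone, is whether a hex-1-en-1-yl chain ending in an amine or a carboxylic acid would return a measurable value.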